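The source may report more compounds than this note shows. Statements on the series, on what has been measured and on what is new or still open speak of the compounds shown alone.

In a functional assay on HeLa cells (Homo sapiens) for cytotoxicity, read by MTT assay (on this read-out higher numbers stand for weaker inhibition and lower numbers for stronger inhibition), compound 1 (`CCCC(O)CC(=O)O[C@H](CC=C(C)C)C1=CC(=O)c2c(O)ccc(O)c2C1=O`) gives 59300 nM and compound 2 (`CC(C)=CC[C@@H](OC(=O)C1CCCOC1)C1=CC(=O)c2c(O)ccc(O)c2C1=O`) gives 60500 nM, so the two stand level within the scatter. Compound 3 (`CCC(O)(CC)CC(=O)O[C@H](CC=C(C)C)C1=CC(=O)c2c(O)ccc(O)c2C1=O`) carries 2-ethyl-2-hydroxybutyl in place of oxan-3-yl on a carbonyl carbon. Among the measured compounds shown here, the only measured step, a 1.0-fold higher number from compound 1 to compound 2 (0.01 log units; within the scatter), put oxan-3-yl in place of 2-hydroxypentyl at that same place and stayed within the scatter. No shift beyond the scatter is therefore expected in this assay. The expected step is a 1.1-fold lower number from compound 2 to compound 3 (0.04 log units; within the scatter). For compound 3 the estimated value is 55000 nM, with an expected range of 28000 nM to 110000 nM.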

Compound 3, half-maximal inhibitory concentration: 52000 nM
Estimate against measurement, compound 3: 1.1-fold (0.02 log units) above; low and high end bracket the measured number.
By their numbers in this assay, from the lowest: compounds 3, 1 and 2 (each within the scatter of the next).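

In this assay, an open chain with a hydrogen-bond donor, 2-ethyl-2-hydroxybutyl, took the place of the ring of oxan-3-yl on a carbonyl carbon, giving a 1.2-fold lower number from compound 2 to compound 3 (0.07 log units; within the scatter). Putting 1-ethyl-1-hydroxypropyl in place of 1-hydroxybutyl on a saturated chain carbon bound to a carbonyl carbon gave a 1.1-fold lower number from compound 1 to compound 3 (0.06 log units; within the scatter), so neither the loss of the ring nor this change in the chain moved the number beyond the scatter. No evidence is available that bears on this result. The compounds shown leave open whether an amine or a carboxylic acid at this place would shift the number beyond the scatter.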